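Swapping Chloro for Nitro on the Aromatic Ring

This account rests on a few compounds, and the source may have more. Where it says the series, first, only, none or still open, it means among the compounds named here.

Two thiosemicarbazones sharing one core have been measured in a functional assay on OVCAR-3 cells (Homo sapiens) for inhibition, read by sulforhodamine B assay, with a stated time of 48 h; a higher number here means a weaker inhibitor of growth, a lower number a stronger inhibitor of growth. Compound 1 `CC1=CC[C@H](C(C)(C)NC(=S)N/N=C/c2ccccc2O)CC1` carries a hydroxy group on the aromatic ring, and in this assay compound 1 gives 5500 nM. Compound 2 `CC1=CC[C@H](C(C)(C)NC(=S)N/N=C/c2ccccc2Cl)CC1` differs only by a chloro group in that position, and in this assay compound 2 gives 15100 nM. The step of a 2.7-fold higher number from compound 1 to compound 2 (0.44 log units; beyond the scatter) is the only one on record; it leaves compound 2 with the highest of the two numbers, compound 1 being its nearest neighbour at a modest distance below.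

Compound 3 `CC1=CC[C@H](C(C)(C)NC(=S)N/N=C/c2ccccc2[N+](=O)[O-])CC1` is not yet measured. It differs from compound 2 as follows: nitro in place of chloro on an aromatic carbon. Among the compounds with values here, no measured step replaces chloro with nitro, so the only step that bears on it is indirect: the hydroxy-to-chloro exchange, a 2.7-fold higher number from compound 1 to compound 2 (0.44 log units; beyond the scatter), which raised the number modestly. That step says nothing direct about a nitro group, so the expectation rests mainly on compound 2 itself. The step of a 1.3-fold lower number from compound 2 to compound 3 (0.10 log units; within the scatter) is expected to remain within the scatter, in no clear direction. The estimate for compound 3 in this assay is 12000 nM, within a range from 4000 nM to 40000 nM.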

Compound 3, concentration for 50% growth inhibition: 8500 nM
Estimate against measurement, compound 3: 1.4-fold (0.15 log units) above; the range from low to high includes it.
By their numbers in this assay, from the lowest: compounds 1, 3 and 2 (each within the scatter of the next, the first and the last beyond it).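

With the nitro group, this position on an aromatic carbon, ortho to a large group, now holds three different substituents, and the new compound cannot be separated from either of the other two: nitro for chloro gives a small step (a 1.8-fold lower number from compound 2 to compound 3 (0.25 log units; within the scatter)), and nitro for hydroxy does too (a 1.5-fold higher number from compound 1 to compound 3 (0.19 log units; within the scatter)). Within the data shown here, the hydroxy-to-chloro exchange (a 2.7-fold higher number from compound 1 to compound 2 (0.44 log units; beyond the scatter)) therefore remains the only step here beyond the scatter, so the nitro group, though it brings more heavy atoms and more hydrogen-bond acceptors than chloro, does not fall clearly with either group and the three compounds do not form a clean series. Nothing in the material shown explains these numbers.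

The compounds shown leave open how an amine, a carboxylic acid or a methoxy group at this same place would read in this assay, and whether any of them would move the number beyond the scatter from all three groups seen so far. They also leave open whether hydroxy, chloro and nitro would keep these relations if placed on another carbon of the aromatic ring.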